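The compounds below may be only part of what the source reports. "The series", "measured", "known", "first", "only" and "open" are said of these compounds alone.

Measured compounds:
compound 1, `Nc1nc(N)c2c(-c3ccccc3)cn([C@@H]3O[C@H](CO)[C@@H](O)[C@H]3O)c2n1`, giving > 20000 nM
compound 2, `CNc1ncnc2c1c(-c1ccccc1)cn2[C@@H]1O[C@H](CO)[C@@H](O)[C@H]1O`, giving > 20000 nM
compound 3, `CNc1ncnc2c1c(-c1cccs1)cn2[C@@H]1O[C@H](CO)[C@@H](O)[C@H]1O`, giving > 20000 nM

All three were tested in a functional assay on CEM-DNR-bulk cells (Homo sapiens), read by MTT assay, with a stated time of 72 h; a lower number here means a stronger inhibitor, a higher number a weaker inhibitor. The value of compound 1 in this assay is a limit of the assay, not a measured number. The same holds for compound 2, whose value is also a limit. The value of compound 3 is a limit as well. Compound 2 and compound 3 differ in one place only, by thiophen-2-yl in place of phenyl on an aromatic carbon. The step between them in this assay, a step that the two limits leave unreadable from compound 2 to compound 3, cannot be read in size, since both ends sit at a limit. Compound 1 and compound 2 have different cores, and the difference between the two cores is not broken down here.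

Compound 4, `Nc1nc(N)c2c(-c3cccs3)cn([C@@H]3O[C@H](CO)[C@@H](O)[C@H]3O)c2n1`, has not yet been measured. Within the data shown here, it differs from compound 1 by thiophen-2-yl in place of phenyl on an aromatic carbon, which is the same change as the one from compound 2 to compound 3. Among the measured compounds shown here, the only guidance for its behaviour is the limit of > 20000 nM in this assay, at which 3 of the 3 values shown sit, so no step size from the measured pair can be carried over. On that basis compound 4 is expected to stay near the limit as well, with an expected step that the limit leaves unreadable from compound 1 to compound 4 in this assay. The estimate for compound 4 is 25000 nM, expected to fall between 8000 nM and 80000 nM.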

Compound 4, half-maximal inhibitory concentration: > 20000 nM
Compound 4: no number, only a limit; the forecaster's own chance of this, stated with the estimate: 85%; the middle value does not contradict the limit.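

No step can be read between compound 1 and compound 4, which differ by thiophen-2-yl in place of phenyl, because both values are limits and not measured numbers: the limit of > 20000 nM in this assay, at which 4 of the 4 values shown sit. The compounds shown leave open how strongly any of them acts in this assay, and whether phenyl or thiophen-2-yl makes any difference to that on either core.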